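A Ring Swap With No Measured Step to Guide It

The compounds below may be only part of what the source reports. "The series", "measured", "known", "first", "only" and "open" are said of these compounds alone.

Compound 1 `Cc1cc(C)c(S(=O)(=O)N2CCC(N3CCC(CCO)CC3)CC2)c(C)c1` is tested in a functional assay on DLD-1 cells (Homo sapiens) for antiproliferative activity, read by CellTiter-Glo, with a stated time of 72 h (on this read-out higher numbers stand for weaker inhibition and lower numbers for stronger inhibition), where compound 1 gives 19 nM. Among the three measured compounds it stands second highest: compound 2 `Cc1cc(C)c(S(=O)(=O)N2CCC(N3CCC(Cc4ccc(F)cc4)CC3)CC2)c(C)c1` gives 18 nM, a step of a 1.1-fold lower number from compound 1 to compound 2 (0.02 log units; within the scatter), while compound 3 `Cc1cc(C)c(S(=O)(=O)N2CCC(N3CCC(Cc4ccccc4F)CC3)CC2)c(C)c1` gives 74 nM, a step of a 3.9-fold higher number from compound 1 to compound 3 (0.59 log units; beyond the scatter). Compound 4 `Cc1cc(C)c(S(=O)(=O)N2CCC(C3OCC(C)CO3)CC2)c(C)c1` differs from compound 1 by a group of 7 heavy atoms (5 carbon, 2 oxygen; one six-membered non-aromatic ring with 2 hetero atoms) in place of a group of 9 heavy atoms (7 carbon, 1 nitrogen, 1 oxygen; one six-membered non-aromatic ring with 1 hetero atom), on a saturated ring carbon. Among the measured compounds shown here, no measured step bears on this change: each measured step alters only the group on the saturated chain carbon, and the largest of them, a 4.1-fold higher number from compound 2 to compound 3 (0.61 log units; beyond the scatter), is modest. For the measured compounds named here, the data hold no step that replaces the whole substituent, so the outcome is uncertain. A weaker result is expected for compound 4, estimated at 200 nM with a range of 30 nM to 1500 nM. That expectation amounts to a step of an 11-fold higher number from compound 1 to compound 4 (1.02 log units; beyond the scatter).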

Compound 4, half-maximal inhibitory concentration: > 5000 nM
Compound 4 was reported as a limit; the forecaster's own chance of this, stated with the estimate: 10%; at least 25-fold (1.39 log units) between middle value and limit.
By their numbers in this assay, from the lowest: compounds 2 and 1 (each within the scatter of the next); then compound 3. At a limit, above all of these: compound 4.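

Earlier steps changed only the group on the saturated chain carbon, and none went beyond modest, whereas replacing the whole 4-(2-hydroxyethyl)piperidin-1-yl group on the saturated ring carbon gives a much larger change: an at least 260-fold higher number from compound 1 to compound 4 (2.42 log units; beyond the scatter). In this assay compound 4 gives a limit, not a number: the limit of > 5000 nM in this assay, at which 1 of the 4 values shown sits. This ring carbon therefore responds far more strongly to exchange of the whole group than the chain carbon does to any change shown.

Which part of the exchange accounts for the step remains open. A piperazine or a dimethylamine on this carbon would separate the role of the ring from that of the amine nitrogen.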